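The source may hold more compounds than are shown below. What is called first, only, known or untested is meant among the compounds shown, and "the series" means these compounds.

Working notes on the series. The shared core is seen in compound 1 `Cc1ccccc1S(=O)(=O)Nc1ccc2oc(-c3ccccc3)nc2c1`, and the compounds differ only in the aryl group on the sulfonyl sulfur. In an assay on cells for inhibition of HSP60/HSP10 (Homo sapiens), with a stated time of 60 min (on this read-out lower numbers stand for stronger inhibition and higher numbers for weaker inhibition), compound 1 reports only a limit of the assay, > 100000 nM. Compound 2 `O=S(=O)(Nc1ccc2oc(-c3ccccc3)nc2c1)c1cccc(F)c1` carries a 3-fluorophenyl there; in this assay compound 2 likewise returns a limit, > 100000 nM. Compound 3 `COc1cccc(S(=O)(=O)Nc2ccc3oc(-c4ccccc4)nc3c2)c1` carries a 3-methoxyphenyl; in this assay compound 3 also stops at a limit, > 100000 nM. The measured steps therefore cannot be read: a step that the two limits leave unreadable from compound 1 to compound 2, a step that the two limits leave unreadable from compound 1 to compound 3 and a step that the two limits leave unreadable from compound 2 to compound 3. All the numbers show is the limit of > 100000 nM in this assay, at which 3 of the 3 values shown sit, so compound 3 stands at that limit with the other two and is not separable from them.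

Compound 4 `O=S(=O)(Nc1ccc2oc(-c3ccccc3)nc2c1)c1ccc(Cl)cc1` differs from compound 3 by 4-chlorophenyl in place of 3-methoxyphenyl on a sulfonyl sulfur. For the measured compounds named here, none of the measured steps gives a readable size, so no direction can be taken from them; the change is again an exchange of one aryl group on the sulfonyl sulfur for another, as in the unreadable steps. For this assay compound 4 is therefore expected to stay around the limit, with an estimate of 150000 nM and a range from 30000 nM to 600000 nM. The implied step, a step that the limit leaves unreadable from compound 3 to compound 4, is expected to be one that a limit leaves unreadable.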

Compound 4, half-maximal inhibitory concentration: > 100000 nM
Compound 4: only a limit was reported (the forecaster's own chance of this, stated with the estimate: 85%); the middle value lies beyond the limit too.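

For the compounds shown here, no step from compound 1, compound 2 or compound 3 to compound 4 can be read, as all four compounds sit at one limit: the limit of > 100000 nM in this assay, at which 4 of the 4 values shown sit. The compounds shown leave open whether any aryl group on the sulfonyl sulfur of the shared core gives a measurable value in this assay.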